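Swapping the alkyne side chain on a sulfonylguanidine scaffold

The compounds below may be only part of what the source reports. "The series", "measured", "known", "first", "only" and "open" are said of these compounds alone.

Measured compounds:
compound 1, `Cc1cc(S(=O)(=O)/N=C(\N)N/N=C/C#Cc2ccccc2)c(SCc2ccc(C(F)(F)F)cc2)cc1Cl`, 105000 nM
compound 2, `C/C(C#Cc1ccccc1)=N\N/C(N)=N/S(=O)(=O)c1cc(C)c(Cl)cc1SCc1ccc(C(F)(F)F)cc1`, 135000 nM
compound 3, `Cc1cc(S(=O)(=O)/N=C(\N)N/N=C/C#Cc2ccccc2)c(SCc2ccc(Cl)cc2)cc1Cl`, 18000 nM

All three were tested in a functional assay on MCF7 cells (Homo sapiens) for antiproliferative activity, read by MTT assay, with a stated time of 72 h; a higher number here means a weaker inhibitor, a lower number a stronger inhibitor. Compound 1 and compound 2 differ by a group of 11 heavy atoms (10 carbon, 1 nitrogen; one six-membered aromatic ring of carbon only) in place of a group of 10 heavy atoms (9 carbon, 1 nitrogen; one six-membered aromatic ring of carbon only), on an amine nitrogen, and this gave a 1.3-fold higher number from compound 1 to compound 2 (0.11 log units; within the scatter). Compound 3 differs from compound 1 by chloro in place of trifluoromethyl on an aromatic carbon, which gave a 5.8-fold lower number from compound 1 to compound 3 (0.77 log units; beyond the scatter). Compound 3 thus has the lowest number of the three, and its steps to both compound 1 and compound 2 lie beyond the scatter.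

Compound 4, `C/C(C#Cc1ccccc1)=N\N/C(N)=N/S(=O)(=O)c1cc(C)c(Cl)cc1SCc1ccc(Cl)cc1`, has not yet been measured. It differs from compound 3 by a group of 11 heavy atoms (10 carbon, 1 nitrogen; one six-membered aromatic ring of carbon only) in place of a group of 10 heavy atoms (9 carbon, 1 nitrogen; one six-membered aromatic ring of carbon only), on an amine nitrogen. For the measured compounds named here, this is the same change as the one from compound 1 to compound 2, made on the same kind of place, so the earlier step is the only guide. Because that change gave a 1.3-fold higher number from compound 1 to compound 2 (0.11 log units; within the scatter), a step of similar size is expected here, estimated as a 1.3-fold higher number from compound 3 to compound 4 (0.11 log units; within the scatter). For compound 4 in this assay the expected value is 23000 nM, with a likely range from 10000 nM to 55000 nM.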

Compound 4, half-maximal inhibitory concentration: 14000 nM
Compound 4: the middle estimate sits 1.6-fold (0.22 log units) above what was measured; the measured number falls inside the stated range.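

In this assay, putting the side chain of 11 heavy atoms in place of the one of 10 heavy atoms on the amine nitrogen gave a 1.3-fold lower number from compound 3 to compound 4 (0.11 log units; within the scatter), so this swap did little on either core: the same change on two cores in this assay, a 1.3-fold higher number (0.11 log units; within the scatter) from compound 1 to compound 2 and a 1.3-fold lower number (0.11 log units; within the scatter) from compound 3 to compound 4, 1.7-fold (0.22 log units) apart, within the scatter of two such steps.
Exchanging trifluoromethyl for chloro on an aromatic carbon gave a 9.6-fold lower number from compound 2 to compound 4 (0.98 log units; beyond the scatter), a step that carries over from one core to the other at a similar size: the same change on two cores in this assay, a 5.8-fold lower number (0.77 log units; beyond the scatter) from compound 1 to compound 3 and a 9.6-fold lower number (0.98 log units; beyond the scatter) from compound 2 to compound 4, 1.7-fold (0.22 log units) apart, within the scatter of two such steps.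
These pairs show that, for the four compounds here, each change behaved alike on the two cores, but they do not show why, nor that the same would hold on a core with a different structure or in another kind of test.

The compounds shown leave open what bromo or methoxy would do on that aromatic carbon, where only trifluoromethyl and chloro appear. They also leave open whether a longer chain in the side chain would be tolerated as well as the two side chains compared here.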